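Triazole ether series: nitro-to-chloro replacements on the benzyl ring

This account rests on a few compounds, and the source may have more. Where it says the series, first, only, none or still open, it means among the compounds named here.

Measured so far in a physicochemical assay, read by spectrophotometry, with a stated time of 30 min; a higher number here means a weaker inhibitor, a lower number a stronger inhibitor:
compound 1, `O=[N+]([O-])c1cccc(Cn2cc(COc3cccc([N+](=O)[O-])c3)nn2)c1`, gives 19.1 ug/mL;
compound 2, `O=[N+]([O-])c1cccc(OCc2cn(Cc3cccc(Cl)c3)nn2)c1`, gives 31.2 ug/mL;
compound 3, `O=[N+]([O-])c1ccc(Cn2cc(COc3c(Cl)cc(Cl)cc3Cl)nn2)cc1`, gives 28.9 ug/mL.

Compound 2 differs from compound 1 by chloro in place of nitro on an aromatic carbon. The step in this assay is a 1.6-fold higher number from compound 1 to compound 2 (0.21 log units; within the scatter), so the two numbers do not separate. Compound 3 differs from compound 1 in more than one place; the difference between the two cores is not broken down here. The numbers of compound 3 and compound 2 also lie within the scatter of each other, as do those of compound 3 and compound 1, so none of the three can be called stronger or weaker than another.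

Compound 4, `Clc1ccc(Cn2cc(COc3c(Cl)cc(Cl)cc3Cl)nn2)cc1`, has not yet been measured. It differs from compound 3 by chloro in place of nitro on an aromatic carbon. The surroundings of the place are not the same as for the earlier pair: there the chloro stands meta to a large group, here it stands para to a large group, so this is the same kind of change, not the same change.

The expectation for compound 4 rests on compound 1 and compound 2, whose step a 1.6-fold higher number from compound 1 to compound 2 (0.21 log units; within the scatter) was small. The estimated step is therefore a 1.5-fold higher number from compound 3 to compound 4 (0.16 log units; within the scatter). For compound 4 the expected number in this assay is 42 ug/mL, estimated to fall between 20 ug/mL and 85 ug/mL.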

Compound 4, half-maximal inhibitory concentration: 27.2 ug/mL
Compound 4: middle estimate off by 1.5-fold (0.19 log units), on the high side, and the stated range covers the measured number.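

In this assay, chloro in place of nitro on an aromatic carbon, para to a large group, gives a 1.1-fold lower number from compound 3 to compound 4 (0.03 log units; within the scatter), while the same kind of change on the core of compound 1 gives a 1.6-fold higher number from compound 1 to compound 2 (0.21 log units; within the scatter). Neither step separates the two compounds it joins, so on both cores shown, this replacement leaves the pair within the scatter, and a nitro-to-chloro swap can be carried between these two cores without a readable shift in this read-out; this rests on two pairs only, and the surroundings of the place are not the same in them, so it is no rule for the series, and neither step gives a direction that could be said to carry over. Nothing on hand gives a reason for either step, or for the two cores behaving alike.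

The compounds shown leave open whether another group in that place, such as an amine, a carboxylic acid or a nitrile, would give a step beyond the scatter on either core. They also leave open whether chloro in place of nitro would stay within the scatter on a third core, or at another place on these two.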